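The source may report more compounds than this note shows. Statements on the series, on what has been measured and on what is new or still open speak of the compounds shown alone.

Measured in a functional assay on U-251 cells (Homo sapiens) for antiproliferative activity, read by sulforhodamine B assay, with a stated time of 48 h; a lower number here means a stronger inhibitor of growth, a higher number a weaker inhibitor of growth:
Compound 1 `CCCCCCCC/C=C\CCCCCCCC(=O)N1CCCC1`: 3.8 ug/mL
Compound 2 `CCCCCCCCCCCCCCCC(=O)N1CCOCC1`: 25 ug/mL
Compound 3 `CCCCCC[C@@H](O)C/C=C\CCCCCCCC(=O)N1CCOCC1`: 33.1 ug/mL

Compound 1, at 3.8 ug/mL, has the lowest number of the three, and its gaps to compound 2 and compound 3 both lie beyond the scatter. The next compound, compound 4 `CCCCCCCC/C=C\CCCCCCCC(=O)N1CCCCC1`, keeps the core of compound 1 and has piperidin-1-yl in place of pyrrolidin-1-yl on a carbonyl carbon. Within the data shown here, no measured pair isolates this change. Compound 2, at 25 ug/mL, and compound 3, at 33.1 ug/mL, differ from compound 1 in more than one place, so they give only a loose guide. The ring swap leaves the rest of the structure untouched, so compound 4 is expected to stay much closer to compound 1 than to those two. The expected change, a 1.6-fold higher number from compound 1 to compound 4 (0.20 log units; within the scatter), is a small one, upward in this assay. For compound 4 the estimated value is 6 ug/mL, with an expected range from 2.5 ug/mL to 15 ug/mL.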

Compound 4, concentration for 50% growth inhibition: 6.7 ug/mL
Estimate against measurement, compound 4: 1.1-fold (0.05 log units) below; measured number inside the range.
By their numbers in this assay, from the lowest: compounds 1 and 4 (each within the scatter of the next); then compounds 2 and 3 (each within the scatter of the next).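

In this assay the change reads a 1.8-fold higher number from compound 1 to compound 4 (0.25 log units; within the scatter) for piperidin-1-yl in place of pyrrolidin-1-yl on a carbonyl carbon, so the two compounds cannot be told apart. Among these compounds, this is the first pair in the set that differs in one place, and it shows that this position tolerates one further ring carbon, with the chain left as it is, without the number leaving the usual scatter of repeated measurements. Nothing available on these compounds offers a reason for this result.

What the compounds shown leave open is whether an open-chain diethylamino group or a piperazin-1-yl ring on the same carbonyl carbon would stay as close to compound 1. Also open, from the compounds shown here alone, is what a free carboxylic acid in place of the whole amide would do on this chain.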